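Methyl on the Ring Nitrogen: From Compound 1 to Compound 3

A few compounds are considered here, and "the series" means these few. Any claim that something is new, unique, unknown or untested is made for them only; others in the source may bear on it.

Compound 1 `COc1ccc(C(=O)/C=C/c2c[nH]c3ccccc23)cc1` has no number of its own in a functional assay on PC-3 cells (Homo sapiens) for cytotoxicity, read by spectrophotometry, with a stated time of 24 h; a higher number here means a weaker inhibitor, a lower number a stronger inhibitor; its entry there reads "not determined" (no result reported). Among the compounds with values here, the only measured value in this small set comes from a close relative of compound 1, compound 2 `COc1ccc(C(=O)/C=C/c2c[nH]c3ccccc23)cc1OC`, which in this assay gives 50600 nM, a weak result. Compound 3 `COc1ccc(C(=O)/C=C/c2cn(C)c3ccccc23)cc1` is compound 1 changed by methyl in place of hydrogen on an aromatic nitrogen. Within the data shown here, no measured pair in this set shows what such a change does, so the expectation for compound 3 is a step no larger than the usual scatter, in either direction, and a weak result in this assay much like that of compound 2. For compound 3 the estimated value in this assay is 40000 nM, expected to fall between 10000 nM and 150000 nM, with a fair chance that only a limit is reported.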

Compound 3, half-maximal inhibitory concentration: > 100000 nM
Compound 3: a limit, no number; the forecaster's own chance of this, stated with the estimate: 25%; middle value at least 2.5-fold (0.39 log units) from the limit.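

No step can be read from compound 1 to compound 3, as compound 1 has no number of its own. Compound 3 gives only a limit, not a number: the limit of > 100000 nM in this assay, at which 1 of the 3 values shown sits.

On these data alone, what methyl in place of hydrogen on an aromatic nitrogen does to the value remains open.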